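This account rests on a few compounds, and the source may have more. Where it says the series, first, only, none or still open, it means among the compounds named here.

Measured compounds:
- compound 1, `Cc1cc(C(=O)Nc2cc(Oc3ccc4nc(NC(=O)C5CC5)nn4c3)ccc2C)n(C)n1`: 53 ug/mL
- compound 2, `Cc1cc(NC(=O)c2cc(C)nn2C)cc(Oc2ccc3nc(NC(=O)C4CC4)nn3c2)c1`: 3.2 ug/mL
- compound 3, `Cc1cc(C(=O)Nc2cccc(Oc3ccc4nc(NC(=O)C5CC5)cn4c3)c2)n(C)n1`: 0.73 ug/mL

In a physicochemical assay for solubility, measured as kinetic solubility, at pH 6.8 (a lower number here means a less soluble compound, a higher number a more soluble compound), compound 3 stands lowest of the three numbers shown. Its nearest neighbour is compound 2, whose value lies beyond the scatter above it; compound 1 lies furthest above it, also well beyond the scatter. Compound 1 carries a methyl on the ring that bears the amide and a different core; compound 2 carries its methyl elsewhere on that ring and shares the core of compound 1.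

Compound 4, `Cc1cc(C(=O)Nc2cc(Oc3ccc4nc(NC(=O)C5CC5)cn4c3)ccc2C)n(C)n1`, is not yet measured in this assay. It differs from compound 3 in one place: methyl in place of hydrogen on an aromatic carbon, on an aromatic carbon of a six-membered aromatic ring of carbon only, ortho to a ((1,3-dimethyl-1H-pyrazol-5-yl)carbonyl)amino group and para to a large group.

For the measured compounds named here, no step between measured compounds isolates this change, so its size is open. Compound 1, which carries the same methyl placement together with a different core, gives 53 ug/mL; on that ground the step from compound 3 to compound 4 is expected to go upward, by a 5.5-fold higher number from compound 3 to compound 4 (0.74 log units; beyond the scatter), beyond the scatter. For compound 4 the estimated value is 4 ug/mL, with a range from 0.8 ug/mL to 20 ug/mL.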

Compound 4, solubility: 2.9 ug/mL
Beside the measured number, compound 4's estimate is 1.4-fold (0.14 log units) above it; measured number inside the range.
By their numbers in this assay, from the lowest: compound 3; then compounds 4 and 2 (each within the scatter of the next); then compound 1.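

In this assay, methyl in place of hydrogen on an aromatic carbon, ortho to a ((1,3-dimethyl-1H-pyrazol-5-yl)carbonyl)amino group and para to a large group, gives a 4.0-fold higher number from compound 3 to compound 4 (0.60 log units; beyond the scatter) on the core shared by these two compounds. For the compounds shown here, this is the first step that isolates the methyl, which earlier appeared only together with a different core in compound 1, and it shows a modest gain beyond the scatter from this single added carbon. No measurement on hand gives a reason for this step.

The size of the step on the core of compound 1 stays open: the compounds shown hold no partner of compound 1 without the methyl. Also open, as far as these compounds go, is how a methoxy group, a fluorine atom or an amine at this position would compare with methyl in this assay on either core.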